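Replacing (2-hydroxyethyl)amino with hydroxy on a carbonyl carbon

This account rests on a few compounds, and the source may have more. Where it says the series, first, only, none or still open, it means among the compounds named here.

In a functional assay on MCF7 cells (Homo sapiens) for cytotoxicity, read by MTT assay, with a stated time of 72 h (on this read-out lower numbers stand for stronger inhibition and higher numbers for weaker inhibition), compound 2 `Cc1oc2ncnc(Nc3cccc(Cl)c3)c2c1C(=O)NCCO` gives > 1000000 nM, which is a limit and not a number. For compound 2 this is the limit of > 1000000 nM in this assay, at which 1 of the 3 values shown sits. Compound 3 `Cc1oc2ncnc(Nc3cccc(Br)c3)c2c1C(=O)NCCO` gives 22000 nM, and compound 1 `CCOC(=O)c1c(C)oc2ncnc(Nc3ccc(OCc4cccc(Cl)c4)cc3)c12` gives 54000 nM. Compound 4 `Cc1oc2ncnc(Nc3cccc(Cl)c3)c2c1C(=O)O` carries hydroxy in place of (2-hydroxyethyl)amino on a carbonyl carbon. For the measured compounds named here, the one measured step, an at least 45-fold lower number from compound 2 to compound 3 (1.65 log units; beyond the scatter), is large, but it is bromo in place of chloro on an aromatic carbon, so it bears only indirectly on this change. With compound 2 at > 1000000 nM, a limit, any measured number in this assay would be lower, and a further limit remains quite possible. The expected change is an at least 3.3-fold lower number from compound 2 to compound 4 (0.52 log units; beyond the scatter). For compound 4 the estimated value is 300000 nM, with an expected range of 40000 nM to 1000000 nM.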

Compound 4, half-maximal inhibitory concentration: 57500 nM
For compound 4 the middle estimate is 5.2-fold (0.72 log units) above the measured one; the measured number falls inside the stated range.
By their numbers in this assay, from the lowest: compound 3; then compounds 1 and 4 (each within the scatter of the next). At a limit, above all of these: compound 2.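

In this assay, hydroxy in place of (2-hydroxyethyl)amino on the carbonyl carbon gives an at least 17-fold lower number from compound 2 to compound 4 (1.24 log units; beyond the scatter). Until now only the bromo in place of chloro change had moved the read-out off a limit, and this shows that a change at the carbonyl carbon can do so too. The true size of this step stays unknown, since compound 2 has only a limit: the limit of > 1000000 nM in this assay, at which 1 of the 4 values shown sits.

The compounds shown leave open whether a primary amide or a longer hydroxyalkyl chain on this carbonyl carbon would give a lower number than compound 4. They also leave open how carboxy would read alongside the bromo of compound 3.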